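Cytotoxicity notes: acylating the aromatic hydroxy of compound 3

The source may hold more compounds than are shown below. What is called first, only, known or untested is meant among the compounds shown, and "the series" means these compounds.

compound 1 (`Cc1c(C)c2c(c(C)c1OC(=O)CCC(=O)O)CCC(C)(C(=O)NCC1CC(C)(C)N([O])C1(C)C)O2`) reads > 300000 nM (a limit)
compound 2 (`Cc1c(C)c2c(c(C)c1OC(=O)CCC(=O)O)CCC(C)(C(=O)O)O2`) reads > 300000 nM (a limit)
compound 3 (`Cc1c(C)c2c(c(C)c1O)CCC(C)(C(=O)NC1CC(C)(C)N([O])C1(C)C)O2`) reads 194000 nM

Within the data shown here, in a toxicity assay on cells (Cricetulus griseus) for cytotoxicity, read by MTT assay, with a stated time of 72 h (a higher number here means a weaker inhibitor, a lower number a stronger inhibitor), compound 3 gives 194000 nM as the only number of the three. Both other compounds sit at a limit (the limit of > 300000 nM in this assay, at which 2 of the 3 values shown sit). Compound 4 (`Cc1c(C)c2c(c(C)c1OC(=O)CCC(=O)O)CCC(C)(C(=O)NC1CC(C)(C)N([O])C1(C)C)O2`) differs from compound 3 by (2-carboxyethyl)carbonyl in place of hydrogen on an oxygen on an aromatic ring (hydroxy to ((2-carboxyethyl)carbonyl)oxy). Among the measured compounds shown here, the one measured step (a step that the two limits leave unreadable from compound 1 to compound 2) sits on a carbonyl carbon and gives no size for this change. Compound 1 carries the (2-carboxyethyl)carbonyl group and reads > 300000 nM as a limit. Compound 2 carries it too and reads > 300000 nM as a limit. A small move toward weaker inhibition is therefore expected in this assay (a 1.5-fold higher number from compound 3 to compound 4 (0.19 log units; within the scatter)). Compound 4 is estimated at 300000 nM (range 150000 nM to 600000 nM) and may report only as a limit.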

Compound 4, half-maximal inhibitory concentration: > 300000 nM
Compound 4: no number, only a limit; the forecaster's own chance of this, stated with the estimate: 70%; the middle value lies on the limit itself.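

In this assay, the (2-carboxyethyl)carbonyl group on an oxygen on an aromatic ring can now be compared directly with the free hydroxy, giving an at least 1.5-fold higher number from compound 3 to compound 4 (0.18 log units; that floor lies within the scatter). From the compounds shown here alone, compound 4 gives only a limit, so this step is a floor and the full size of the change remains unknown. Compound 4 also joins the compounds that give no number: the limit of > 300000 nM in this assay, at which 3 of the 4 values shown sit.

The steps among compound 1, compound 2 and compound 4 cannot be read. Going by these compounds, whether an acetyl group or an amine-bearing chain on the same oxygen would give a number in this assay remains open.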